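The compounds below may be only part of what the source reports. "The series", "measured", "known", "first", "only" and "open" are said of these compounds alone.

Compound 2 `O=C(CSc1nnc(-c2ccncc2)o1)N/N=C/c1cc(Br)ccc1O` is tested in a functional assay on MCF7 cells (Homo sapiens) for cytotoxicity, read by MTT assay, with a stated time of 48 h (a lower number here means a stronger inhibitor, a higher number a weaker inhibitor), where compound 2 gives 7770 nM. Within the data shown here, that is the lowest of the two numbers so far, yet its only neighbour, compound 1 `O=C(CSc1nnc(-c2ccncc2)o1)N/N=C/c1ccc(F)cc1`, gives 13500 nM, and the step of a 1.7-fold lower number from compound 1 to compound 2 (0.24 log units; within the scatter) lies within the scatter, so the two cannot be told apart. Compound 3 `O=C(CSc1nnc(-c2ccncc2)o1)N/N=C/c1ccco1` is not yet measured. It differs from compound 2 in one place: furan-2-yl in place of 5-bromo-2-hydroxyphenyl on a carbon with a double bond to nitrogen. Among the measured compounds shown here, the one measured step, a 1.7-fold lower number from compound 1 to compound 2 (0.24 log units; within the scatter), also changed the group on a carbon with a double bond to nitrogen and stayed within the scatter, so for compound 3 the expected step is a 1.3-fold higher number from compound 2 to compound 3 (0.11 log units; within the scatter), with no change beyond the scatter. Compound 3 is therefore estimated at 10000 nM, in a range from 4000 nM to 30000 nM.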

Compound 3, half-maximal inhibitory concentration: 16600 nM
Beside the measured number, compound 3's estimate is 1.7-fold (0.22 log units) below it; low and high end bracket the measured number.
By their numbers in this assay, from the lowest: compounds 2, 1 and 3 (each within the scatter of the next, the first and the last beyond it).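

In this assay the group on a carbon with a double bond to nitrogen now gives its first step beyond the scatter: furan-2-yl in place of 5-bromo-2-hydroxyphenyl gives a 2.1-fold higher number from compound 2 to compound 3 (0.33 log units; beyond the scatter), a modest change. Furan-2-yl in place of 4-fluorophenyl gives a 1.2-fold higher number from compound 1 to compound 3 (0.09 log units; within the scatter), so these two groups cannot be told apart here. A five-membered aromatic ring can therefore stand at this position with little change from compound 1, but the gap to compound 2 is only just beyond the scatter.

From the compounds shown here alone, how an amine or a carboxylic acid at this position would behave remains open. No measurement shown here explains the difference between compound 2 and compound 3.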